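The source may report more compounds than this note shows. Statements on the series, on what has been measured and on what is new or still open speak of the compounds shown alone.

In an assay on isolated protein for inhibition of Trypsin (Homo sapiens) (a lower number here means a stronger inhibitor, a higher number a weaker inhibitor), compound 1 `Cc1nn(-c2cccc(CN)c2)c2c(F)c(-c3ccc(N4CCCCC4=O)cc3)ccc12` gives 1900 nM. Compound 2 `CN(C)Cc1[nH]ncc1-c1ccc(-c2ccc3c(C(N)=O)nn(-c4ccc5onc(N)c5c4)c3c2F)c(F)c1` reaches only a limit of the assay, > 10000 nM, so its true inhibition constant is not known; it sits at the limit of > 10000 nM in this assay, at which 1 of the 2 values shown sits. Compound 3 `CN(C)CCN(c1cccnc1)c1ccc(-c2ccc3c(C(N)=O)nn(-c4ccc5onc(N)c5c4)c3c2F)c(F)c1` differs from compound 2 by (2-(dimethylamino)ethyl)(pyridin-3-yl)amino in place of 5-((dimethylamino)methyl)-1H-pyrazol-4-yl on an aromatic carbon, with (2-(dimethylamino)ethyl)(pyridin-3-yl)amino in place of 5-((dimethylamino)methyl)-1H-pyrazol-4-yl on an aromatic carbon. Among the measured compounds shown here, no measured step of this kind exists, so the expected step is a step that the limit leaves unreadable from compound 2 to compound 3, within the usual scatter. Compound 3 is expected to give about 15000 nM, between 4000 nM and 50000 nM, quite possibly again reported only as a limit.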

Compound 3, inhibition constant: > 10000 nM
Compound 3 ended at the assay's limit; the forecaster's own chance of this, stated with the estimate: 60%; the middle value is on the limit's open side.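

Among the compounds shown here, compound 2 and compound 3 both stand at a limit of this assay, so no step between them can be read: the limit of > 10000 nM in this assay, at which 2 of the 3 values shown sit. Going by these compounds, the true inhibition constants of compound 2 and compound 3, and how far apart they lie, remain open.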